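The source may report more compounds than this note shows. Statements on the series, on what has been measured and on what is new or still open speak of the compounds shown alone.

Of the compounds shown here, three sharing one core have been tested in an ADME assay on Huh-7 cells (Homo sapiens) for cytotoxicity, read by a luciferase reporter and WST assay, with a stated time of 3 days; a higher number here means that more compound is tolerated, a lower number that less compound is tolerated. Compound 1 `O=C(Nc1ccc(Cl)cc1)c1c(NO)cc(-c2ccccc2)oc1=O` reaches only the limit of the assay there, giving > 20000 nM. Compound 2 `Cc1ccc(NC(=O)c2c(NO)cc(-c3ccc(C)cc3)oc2=O)cc1` likewise stops at the limit, with > 20000 nM. Compound 3 `CNC(=O)c1c(NO)cc(-c2ccc(F)cc2)oc1=O` also returns only a limit, > 20000 nM. So compound 1 stands at the limit rather than at a number, and it shares this position with the other two because the limit of > 20000 nM in this assay, at which 3 of the 3 values shown sit, places all three values there. Among the measured compounds shown here, no step between these compounds can therefore be sized. Compound 4 `O=C(NCCCO)c1c(NO)cc(-c2ccccc2)oc1=O` differs from compound 1 in one place: 3-hydroxypropyl in place of 4-chlorophenyl on an amide-type nitrogen. With every measured value at the limit, the step expected in this assay is a step that the limit leaves unreadable from compound 1 to compound 4, none beyond the scatter. Compound 4 is expected to give 30000 nM, within 15000 nM to 60000 nM, most likely again as a limit.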

Compound 4, half-maximal cytotoxic concentration: > 20000 nM
Compound 4: only a limit was reported; the forecaster's own chance of this, stated with the estimate: 85%; the middle value lies beyond the limit too.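

Among the compounds shown here, no step from compound 1 to compound 4 can be read, because both stop at a limit rather than a number: the limit of > 20000 nM in this assay, at which 4 of the 4 values shown sit.

The compounds shown leave open what concentration, if any, would reach the half-maximal cytotoxic point in this assay for any of them.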